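The source may report more compounds than this note shows. Statements on the series, on what has been measured and on what is new or still open speak of the compounds shown alone.

Measured so far:
- compound 1, `CCC(C(=O)N1CCN(c2cccc(C(F)(F)F)c2)CC1)N1C(=O)CC(C)C1=O`: 30.3 mg/kg
- compound 2, `CCC(C(=O)N1CCN(c2cccc(Cl)c2)CC1)N1C(=O)CC(C)C1=O`: 43.5 mg/kg
- compound 3, `CC(C(=O)N1CCN(c2cccc(Cl)c2)CC1)N1C(=O)CC(C)(C)C1=O`: 19.8 mg/kg

All three were tested in a functional assay on the whole organism (strain Swiss) with Mus musculus as the target, with a stated time of 0.25 h; a lower number here means that less compound is needed, a higher number that more compound is needed for the effect. Compound 2 and compound 1 share one core and differ in a single group on the aromatic ring: trifluoromethyl in place of chloro on an aromatic carbon. That exchange gave a 1.4-fold lower number from compound 2 to compound 1 (0.16 log units; within the scatter). Compound 3 is built on a different core, made of the same atoms as compound 2 but joined differently; the difference between the two cores is not broken down here. In this assay compound 3 gives a number close to that of compound 1, while the gap from compound 3 to compound 2 lies beyond the scatter.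

Compound 4, `CC(C(=O)N1CCN(c2cccc(C(F)(F)F)c2)CC1)N1C(=O)CC(C)(C)C1=O`, has not yet been measured. It stands to compound 3 exactly as compound 1 stands to compound 2: trifluoromethyl in place of chloro on an aromatic carbon. Among the compounds shown, this exchange of chloro for trifluoromethyl occurs two times in all, and the surroundings of the changed position are described in identical words for both pairs, so it is the same change. Among the compounds with values here, the only measured example of it, from compound 2 to compound 1, is small and within the scatter.

On that basis the step from compound 3 to compound 4 is expected to be a 1.4-fold lower number from compound 3 to compound 4 (0.14 log units; within the scatter), a small downward shift that could equally come out flat. In this assay compound 4 is therefore estimated at 14.5 mg/kg, with a likely range from 8 mg/kg to 27 mg/kg.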

Compound 4, dose for half-maximal effect: 29 mg/kg
Beside the measured number, compound 4's estimate is 2.0-fold (0.30 log units) below it; measured number above the stated range.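

In this assay, trifluoromethyl in place of chloro on the core of compound 3 gave a 1.5-fold higher number from compound 3 to compound 4 (0.17 log units; within the scatter). The two available steps carry opposite signs, but each lies within the scatter, and so does the gap between them: the same change on two cores in this assay, a 1.4-fold lower number (0.16 log units; within the scatter) from compound 2 to compound 1 and a 1.5-fold higher number (0.17 log units; within the scatter) from compound 3 to compound 4, 2.1-fold (0.32 log units) apart, within the scatter of two such steps. This shows that, on both cores, the exchange of chloro for trifluoromethyl leaves the number within the usual scatter of repeated measurements, so the small step seen on one core was also small on the other; it does not show that the two groups are interchangeable in general, and two pairs are too few to tell whether the cores truly respond alike or differ slightly in a way hidden by the scatter.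

The compounds shown leave open whether another group in the same place on the aromatic ring, such as a methoxy group or a nitrile, would give a step beyond the scatter on either core. They also leave open which part of the difference between the two cores matters for the number in this assay, since no pair shown separates those parts one at a time.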